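A few compounds are considered here, and "the series" means these few. Any claim that something is new, unique, unknown or untested is made for them only; others in the source may bear on it.

Measured in a physicochemical assay for metabolic stability, read by HPLC and mass spectrometry, in phosphate buffer, at 37 degrees C, at pH 7.4; a lower number here means that the compound disappears faster, a higher number that the compound lasts longer:
- Compound 1 `CC(C)(O/N=C(\C(=O)N[C@@H]1C(=O)N(S(=O)(=O)O)[C@@H]1CN1CCNC1=O)c1csc(N)n1)C(=O)O`: > 1000 h, a limit
- Compound 2 `CC(C)(O/N=C(\C(=O)N[C@@H]1C(=O)N(S(=O)(=O)O)[C@@H]1Cn1cncn1)c1csc(N)n1)C(=O)O`: 233 h
- Compound 3 `CC(C)(O/N=C(\C(=O)N[C@@H]1C(=O)N(S(=O)(=O)O)[C@@H]1CN1C[C@H](CN)OC1=O)c1csc(N)n1)C(=O)O`: > 37 h, a limit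

Compound 3 has no exact number, as its > 37 h is only a limit. The next compound, compound 4 `CC(C)(O/N=C(\C(=O)N[C@@H]1C(=O)N(S(=O)(=O)O)[C@@H]1Cn1ncnc1CNC(=N)N)c1csc(N)n1)C(=O)O`, differs from it by a group of 10 heavy atoms (4 carbon, 6 nitrogen; one five-membered aromatic ring with 3 hetero atoms) in place of a group of 8 heavy atoms (4 carbon, 2 nitrogen, 2 oxygen; one five-membered non-aromatic ring with 2 hetero atoms), on a saturated chain carbon bound to a saturated ring carbon. The new group has a five-membered aromatic ring with 3 hetero atoms, and so does the 1H-1,2,4-triazol-1-yl of compound 2.

Going by the values given here, only one measured step has a readable size: an at least 4.2-fold lower number from compound 1 to compound 2 (0.63 log units; beyond the scatter). Two others cannot be sized: a step that the two limits leave unreadable from compound 1 to compound 3 and a step that the limit leaves unreadable from compound 2 to compound 3. None of these steps tests the full new group, so the closest guide is compound 2 at 233 h. Compound 4 is therefore expected to fall near that value in this assay, perhaps a little lower.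

With only a limit for compound 3, the direction of the change stays uncertain, and the estimated step is a step that the limit leaves unreadable from compound 3 to compound 4. The estimate for compound 4 is 180 h, with an expected range from 50 h to 700 h.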

Compound 4, half-life: > 37 h
Compound 4 ended at the assay's limit; the forecaster's own chance of this, stated with the estimate: 25%; the middle value lies beyond the limit too.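

In this assay compound 4 gives > 37 h, which is a limit. Its steps from compound 1, compound 2 and compound 3 cannot be read. The compounds shown leave open whether the group which compound 4 carries in place of a hydrogen atom of compound 2 changes the half-life.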